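The source may hold more compounds than are shown below. What is called first, only, known or untested is meant among the compounds shown, and "the series" means these compounds.

For the measured compounds named here, compound 2 `COc1ncc(C(CC(=O)O)CC2CCN(C(=O)CCc3ccc4c(n3)NCCC4)CC2)c(OC)n1` gives 49.8 ng.h/mL in an ADME assay on the whole organism (plasma, Rattus norvegicus) for pharmacokinetics, at a dose of 10 mg/kg by the oral route (a higher number here means more compound in the circulation at the dose given, a lower number less compound in the circulation), the lower of the two numbers known so far; compound 1 `O=C(O)CC(CC1CCN(C(=O)CCc2ccc3c(n2)NCCC3)CC1)c1cccc(F)c1` gives 1220 ng.h/mL in the same assay. Going by the values given here, the one measured step, a 24-fold lower number from compound 1 to compound 2 (1.39 log units; beyond the scatter), came with a 2,4-dimethoxypyrimidin-5-yl in place of 3-fluorophenyl. Compound 3 `O=C(O)CC(CC1CCN(C(=O)CCc2ccc3c(n2)NCCC3)CC1)c1ccc2ccccc2c1` carries naphthalen-2-yl in place of 2,4-dimethoxypyrimidin-5-yl on a saturated chain carbon bound to two saturated chain carbons, removing that same ring again, so the measured step bears on it in the opposite direction. A large rise beyond the scatter is therefore expected, estimated as a 12-fold higher number from compound 2 to compound 3 (1.08 log units; beyond the scatter). Compound 3 is expected to give about 600 ng.h/mL in this assay, within a range of 150 ng.h/mL to 2500 ng.h/mL.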

Compound 3, area under the concentration-time curve: 139000 ng.h/mL
Beside the measured number, compound 3's estimate is 230-fold (2.36 log units) below it; the whole stated range lies below it.
By their numbers in this assay, from the lowest: compound 2; then compound 1; then compound 3.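

In this assay, changing only the ring on this saturated chain carbon gives a 2800-fold higher number from compound 2 to compound 3 (3.45 log units; beyond the scatter) and a 110-fold higher number from compound 1 to compound 3 (2.06 log units; beyond the scatter). The position therefore allows large rises as well as the earlier fall, and naphthalen-2-yl, with 2 six-membered aromatic rings of carbon only, stands far above both other groups. Nothing measured here explains the size of these changes.

As far as these compounds go, whether the second ring or the absence of ring nitrogen and methoxy groups goes with the rise remains open. Quinolin-3-yl, a two-ring group containing a ring nitrogen, would help separate the two.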